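Lengthening the chain on the quinoline-linked isoxazoles

The compounds below may be only part of what the source reports. "The series", "measured", "known", "first", "only" and "open" are said of these compounds alone.

Measured compounds:
compound 1, `CCCCCc1cc2ccccc2nc1-c1cc(-c2ccccc2)no1`, > 100000 nM
compound 2, `CCCc1cc2ccccc2nc1-c1cc(-c2ccc(C(F)(F)F)cc2)no1`, 36500 nM
compound 3, `CCCCc1cc2ccccc2nc1-c1cc(-c2ccc(C(F)(F)F)cc2)no1`, 10400 nM

In a functional assay on MDA-MB-231 cells (Homo sapiens) for inhibition, read by MTT assay, with a stated time of 24 h (a lower number here means a stronger inhibitor, a higher number a weaker inhibitor), compound 3 gives 10400 nM, the lowest of the two numbers measured; its nearest neighbour is compound 2, with 36500 nM. For compound 1 this assay reports only a limit, (the limit of > 100000 nM in this assay, at which 1 of the 3 values shown sits), and not a number. Compound 4, `CCCCCc1cc2ccccc2nc1-c1cc(-c2ccc(C(F)(F)F)cc2)no1`, is not yet measured. It differs from compound 3 by methyl in place of hydrogen on a saturated chain carbon, four bonds along the chain from an aromatic carbon. Within the data shown here, one measured step bears on this change: a 3.5-fold lower number from compound 2 to compound 3 (0.55 log units; beyond the scatter). Compound 4 repeats that kind of change one bond further out. Among the measured compounds shown here, compound 1 carries the same chain as compound 4 but a plain phenyl in place of the trifluoromethyl-bearing one, and its value in this assay sits at the limit; no step is known between it and compound 4. A further modest gain is therefore expected, smaller than the measured one, with a wide range: a 1.5-fold lower number from compound 3 to compound 4 (0.17 log units; within the scatter). Compound 4 is estimated at 7000 nM, between 2500 nM and 30000 nM.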

Compound 4, half-maximal inhibitory concentration: 22100 nM
The estimate for compound 4 lay 3.2-fold (0.50 log units) below the measured number; measured number inside the range.
By their numbers in this assay, from the lowest: compound 3; then compounds 4 and 2 (each within the scatter of the next). At a limit, above all of these: compound 1.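

In this assay, the gain from lengthening the chain did not continue at this position: methyl in place of hydrogen, four bonds along the chain from an aromatic carbon, gives a 2.1-fold higher number from compound 3 to compound 4 (0.33 log units; beyond the scatter). Compound 3 therefore holds the lowest number among the three trifluoromethyl compounds, while the comparison of the two chains on either side of it gives a 1.7-fold lower number from compound 2 to compound 4 (0.22 log units; within the scatter), so the series shows no steady trend with chain length. Trifluoromethyl in place of hydrogen on an aromatic carbon gives an at least 4.5-fold lower number from compound 1 to compound 4 (0.65 log units; beyond the scatter), a step that starts from a limit and not a number: the limit of > 100000 nM in this assay, at which 1 of the 4 values shown sits.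

The compounds shown leave open whether a longer chain, or a chain ending in an amine or a carboxylic acid, would lower the number again. They also leave open how a chlorine or a nitrile would compare with trifluoromethyl on the same aromatic carbon.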